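Swapping the fluorinated aromatic group of compound 3

This account rests on a few compounds, and the source may have more. Where it says the series, first, only, none or still open, it means among the compounds named here.

Compound 1 `OC[C@H]1O[C@@H](n2cnc3c(NCc4ccccc4Cl)ncnc32)[C@H](O)[C@@H]1O` gives 1600 nM
Compound 2 `COc1ccccc1CNc1ncnc2c1ncn2[C@@H]1O[C@H](CO)[C@@H](O)[C@H]1O` gives 2300 nM
Compound 3 `OC[C@H]1O[C@@H](n2cnc3c(NCc4ccc(F)cc4F)ncnc32)[C@H](O)[C@@H]1O` gives 3400 nM

All three numbers come from a functional assay on HL-60 cells (Homo sapiens) for antiproliferative activity, with a stated time of 72 h (on this read-out lower numbers stand for stronger inhibition and higher numbers for weaker inhibition), and describe compounds that share one core and differ only in the aromatic group on the chain. Compound 3 stands only modestly apart from compound 1: the data show a 2.1-fold higher number from compound 1 to compound 3 (0.33 log units; beyond the scatter) and mark it as a small move. Compound 3 cannot be told apart from compound 2, given a 1.5-fold higher number from compound 2 to compound 3 (0.17 log units; within the scatter) here. The remaining pair shows a 1.4-fold higher number from compound 1 to compound 2 (0.16 log units; within the scatter) as well.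

Compound 4 `OC[C@H]1O[C@@H](n2cnc3c(NCc4c(F)ccc(F)c4F)ncnc32)[C@H](O)[C@@H]1O` has not yet been measured. It carries 2,3,6-trifluorophenyl in place of 2,4-difluorophenyl on a saturated chain carbon bound to a nitrogen on an aromatic ring. The three measured steps are the best guide, since each one changes this same aromatic group, and none of them is larger than modest. Among the measured compounds shown here, no measured compound has three fluorines, so the data offer no direction. In this assay the expected outcome is therefore no step beyond the scatter, and the step estimated is a 1.2-fold lower number from compound 3 to compound 4 (0.08 log units; within the scatter) in size. The estimate for compound 4 is 2800 nM with an expected range from 1300 nM to 6000 nM on repeated measurement.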

Compound 4, half-maximal inhibitory concentration: 13000 nM
Beside the measured number, compound 4's estimate is 4.6-fold (0.67 log units) below it; measured number above the stated range.
By their numbers in this assay, from the lowest: compounds 1, 2 and 3 (each within the scatter of the next, the first and the last beyond it); then compound 4.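

In this assay, among the compounds shown here, the aromatic group on this chain carbon proves less forgiving than the earlier compounds suggested: the three earlier groups stay in a narrow band, yet 2,3,6-trifluorophenyl in place of 2,4-difluorophenyl gives a 3.8-fold higher number from compound 3 to compound 4 (0.58 log units; beyond the scatter) and is the first change on this group to move the number clearly. The same weakening appears against the two non-fluorinated comparisons, with a 5.7-fold higher number from compound 2 to compound 4 (0.75 log units; beyond the scatter) and an 8.1-fold higher number from compound 1 to compound 4 (0.91 log units; beyond the scatter), which makes compound 4 the weakest of the four, since all its steps lie beyond the scatter. No measurement shown here accounts for why this particular fluorine pattern costs so much activity.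

This single change adds a third fluorine and also rearranges the fluorines, so the compounds shown cannot say whether the number of fluorines or their arrangement matters more. A 2,6-difluorophenyl group would help separate those two effects, and a phenyl ring carrying an amine or a carboxylic acid would show whether this position tolerates anything beyond halogens and methoxy.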